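The source may hold more compounds than are shown below. What is called first, only, known or untested is meant among the compounds shown, and "the series" means these compounds.

Measured so far:
compound 1 `COc1ccc(S(=O)(=O)N2CCc3cccc(-c4ccc([N+](=O)[O-])cc4)c32)cc1`: 51.3 nM
compound 2 `COc1ccc(S(=O)(=O)n2ccc3cccc(-c4ccc(F)cc4)c32)cc1`: 202 nM

Both numbers come from a functional assay on KB-VIN10 cells (Homo sapiens) for inhibition, with a stated time of 72 h; on this read-out lower numbers stand for stronger inhibition and higher numbers for weaker inhibition. Compound 1 gives 51.3 nM, the lowest of the two numbers seen; compound 2 comes next, and the gap between them lies beyond the usual scatter, so compound 1 stands as the stronger inhibitor of the pair. Compound 3 `COc1ccc(S(=O)(=O)N2CCc3cccc(-c4ccccc4)c32)cc1` has not yet been measured. It is reached from compound 1 by a single change: hydrogen in place of nitro on an aromatic carbon. The nitro group leaves the six-membered aromatic ring of carbon only, where it sat para to a large group, and a hydrogen atom enters in its place; cut one bond further out, 4-nitrophenyl becomes phenyl. Among the measured compounds shown here, no measured pair shows this change on its own, so its size cannot be read from the data. The expectation is that compound 3 shows a modest loss of inhibition, a step of a 2.9-fold higher number from compound 1 to compound 3 (0.47 log units; beyond the scatter) pointing to a higher number. Compound 3 is therefore estimated at 150 nM, within 40 nM to 550 nM.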

Compound 3, half-maximal inhibitory concentration: 107 nM
For compound 3 the middle estimate is 1.4-fold (0.15 log units) above the measured one, within the range that was stated.
By their numbers in this assay, from the lowest: compound 1; then compounds 3 and 2 (each within the scatter of the next).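

Taking the nitro group off the 4-nitrophenyl ring gives the first change in this set that can be read on its own: in this assay, the step is a 2.1-fold higher number from compound 1 to compound 3 (0.32 log units; beyond the scatter), modest but beyond the usual scatter. Inhibition therefore does not depend on the nitro group, as the plain phenyl of compound 3 still gives 107 nM, although the nitro group does go with the lower number on this core. Nothing at hand accounts for the size of this step.

Still open, going by these compounds, is how other groups at this same place, such as an amine or a carboxylic acid, would compare with nitro and hydrogen. Also open, on these data alone, is whether the same change would give a similar step on the core of compound 2.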